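Cytotoxicity at the ring nitrogen: from compound 2 to compound 3

The source may hold more compounds than are shown below. What is called first, only, known or untested is meant among the compounds shown, and "the series" means these compounds.

The series shares one core, seen in compound 1 `COc1ccc([C@H]2CC(=O)N(Cc3cccc([N+](=O)[O-])c3)C2)cc1OC1CCCC1` and compound 2 `COc1ccc([C@H]2CC(=O)N(c3cc(N)cc(F)c3)C2)cc1OC1CCCC1`, and is tested in a functional assay on HEK293 cells (Homo sapiens) for cytotoxicity; on this read-out lower numbers stand for higher toxicity in this test and higher numbers for lower toxicity in this test. In this assay compound 1 gives > 10000 nM, which is a limit of the assay rather than a number. Compound 2 likewise gives > 10000 nM, again a limit and not a number. Among the compounds with values here, the step that the two limits leave unreadable from compound 1 to compound 2 therefore cannot be read, and the only evidence on the measured pairs is the limit of > 10000 nM in this assay, at which 2 of the 2 values shown sit.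

Compound 3 `COc1ccc([C@H]2CC(=O)N(c3ccc([S+](C)[O-])cc3)C2)cc1OC1CCCC1` is the next compound to be measured. It differs from compound 2 in one place: a group of 9 heavy atoms (7 carbon, 1 oxygen, 1 sulfur; one six-membered aromatic ring of carbon only) in place of a group of 8 heavy atoms (6 carbon, 1 nitrogen, 1 fluorine; one six-membered aromatic ring of carbon only), on an amide-type nitrogen in a ring. The group that enters carries 1 oxygen and 1 sulfur and no hydrogen-bond donor, where the 3-amino-5-fluorophenyl that leaves carried 1 hydrogen-bond donor.

Within the data shown here, no measured step bears on this change with a readable size, since both values so far sit at the same limit. On that basis compound 3 is expected to show a step that the limit leaves unreadable from compound 2 to compound 3, that is, no step beyond the scatter in this assay. Compound 3 is estimated at 15000 nM, within a range from 7000 nM to 40000 nM, most likely reported once more as a limit.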

Compound 3, half-maximal cytotoxic concentration: 7510 nM
Beside the measured number, compound 3's estimate is 2.0-fold (0.30 log units) above it; low and high end bracket the measured number.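

In this assay compound 3 is the first of the compounds shown to give a number rather than a limit, so a group on the amide-type nitrogen can now be tied to a readable value in this test. Against the 3-amino-5-fluorophenyl, the change gives an at least 1.3-fold lower number from compound 2 to compound 3 (0.12 log units; that floor lies within the scatter), and against the 3-nitrobenzyl it gives an at least 1.3-fold lower number from compound 1 to compound 3 (0.12 log units; that floor lies within the scatter). Both steps are floors that do not pass the scatter, so the data do not establish a real shift at this position, and the other values shown remain a limit: the limit of > 10000 nM in this assay, at which 2 of the 3 values shown sit.

Going by these compounds, the true size of either step stays open, as does the question of whether the number follows the sulfur and oxygen of the entering group or the loss of the hydrogen-bond donor, since these two differences arrive together in a single change. On these data alone, how a sulfone or a carboxylic acid on the aromatic ring at this amide-type nitrogen would read in this assay also remains open.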